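Trifluoromethoxy for fluoro, starting from a limit

The compounds below may be only part of what the source reports. "The series", "measured", "known", "first", "only" and "open" are said of these compounds alone.

compound 1 `Cc1ccc2nc(-c3ccccc3C(F)(F)F)[nH]c(=O)c2c1`: > 50000 nM
compound 2 `CCN(CC)c1ccc2nc(-c3ccccc3OC(F)(F)F)[nH]c(=O)c2c1`: 1670 nM
compound 3 `Cc1ccc2nc(-c3ccccc3F)[nH]c(=O)c2c1`: > 50000 nM

In a functional assay on T47D cells (Homo sapiens) for cytotoxicity, read by MTT assay, with a stated time of 2 days (on this read-out lower numbers stand for stronger inhibition and higher numbers for weaker inhibition), compound 3 gives > 50000 nM, which is a limit and not a number. Compound 1 gives > 50000 nM, also a limit. Compound 3 therefore stands at the limit of > 50000 nM in this assay, at which 2 of the 3 values shown sit.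

Compound 4 `Cc1ccc2nc(-c3ccccc3OC(F)(F)F)[nH]c(=O)c2c1` carries trifluoromethoxy in place of fluoro on an aromatic carbon, ortho to a large group: trifluoromethoxy in place of fluoro on an aromatic carbon.

Going by the values given here, the one measured step between closely related compounds is a step that the two limits leave unreadable from compound 1 to compound 3, so it supplies no size to carry over. Among the compounds with values here, compound 2 also carries trifluoromethoxy and gives 1670 nM, a real number, but no measured step connects it to compound 4. A move towards stronger inhibition is therefore possible, though a result close to the limit remains the likelier outcome. The expected change is an at least 1.6-fold lower number from compound 3 to compound 4 (0.22 log units; that floor lies within the scatter). In this assay the estimated value for compound 4 is 30000 nM, with an expected range of 6000 nM to 50000 nM.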

Compound 4, half-maximal inhibitory concentration: > 50000 nM
Compound 4: no number, only a limit (the forecaster's own chance of this, stated with the estimate: 55%); middle value at least 1.6-fold (0.22 log units) away from the limit.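

In this assay, compound 4 is a limit and not a number, so trifluoromethoxy in place of fluoro on an aromatic carbon, ortho to a large group, leaves the methyl compound without a readable value; the steps to compound 4 from compound 1 and compound 3 cannot be read. With trifluoromethoxy common to both compounds, the series gains its first readable step, an at least 29-fold higher number from compound 2 to compound 4 (1.47 log units; beyond the scatter), for methyl in place of diethylamino on an aromatic carbon. Trifluoromethoxy alone thus does not carry compound 2's number, and compound 4 joins the compounds at the limit: the limit of > 50000 nM in this assay, at which 3 of the 4 values shown sit.

From the compounds shown here alone, whether diethylamino would give a number alongside fluoro or trifluoromethyl remains open. Also open, going by these compounds, is how a smaller amine such as dimethylamino, or a carboxylic acid, would read in place of methyl.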